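The source may report more compounds than this note shows. Statements on the series, on what has been measured and on what is new or still open speak of the compounds shown alone.

Measured so far:
- compound 1 `O=S(=O)(NCCCCCCNCc1ccc(Br)cc1)c1cc(Cl)cc(Cl)c1`: 12000 nM
- compound 2 `O=S(=O)(NCCCCCCNCc1ccc(Br)cc1)c1ccc(C(F)(F)F)cc1`: 3830 nM
- compound 3 `O=S(=O)(NCCCCCCNCc1ccc(Br)cc1)c1ccc2c(c1)OCC2`: 13000 nM

All three share a long-chain sulfonamide core and differ only in the aromatic group on the sulfonyl sulfur. In a functional assay on MIA PaCa-2 cells (Homo sapiens) for inhibition, read by MTT assay, with a stated time of 72 h (on this read-out lower numbers stand for stronger inhibition of growth and higher numbers for weaker inhibition of growth), compound 3 gives the highest number of the three; compound 1 sits close to it, within the scatter, whereas compound 2 gives a clearly lower number, beyond the scatter.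

Compound 4 `O=S(=O)(NCCCCCCNCc1ccc(Br)cc1)c1c(Cl)cccc1Cl` is the next step from compound 3. The change is a group of 8 heavy atoms (6 carbon, 2 chlorine; one six-membered aromatic ring of carbon only) in place of a group of 9 heavy atoms (8 carbon, 1 oxygen; one five-membered non-aromatic ring with 1 hetero atom, one six-membered aromatic ring of carbon only), on a sulfonyl sulfur. Among the measured compounds shown here, one measured step bears on it directly: the move in the opposite direction, a 1.1-fold higher number from compound 1 to compound 3 (0.03 log units; within the scatter), swapped a dichlorophenyl for the same bicyclic group and changed nothing beyond the scatter. Compound 4 carries the two chlorines in a different arrangement from compound 1, so the comparison is not exact, but it is the closest guide available. The expected step in this assay is therefore small, a 1.3-fold lower number from compound 3 to compound 4 (0.11 log units; within the scatter), in the direction of a slightly lower number at most. Compound 4 is estimated at 10000 nM, within a range from 3500 nM to 30000 nM.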

Compound 4, concentration for 50% growth inhibition: 14700 nM
Beside the measured number, compound 4's estimate is 1.5-fold (0.17 log units) below it; the range from low to high includes it.
By their numbers in this assay, from the lowest: compound 2; then compounds 1, 3 and 4 (each within the scatter of the next).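

In this assay, 2,6-dichlorophenyl on the sulfonyl sulfur cannot be told apart from the group of 9 heavy atoms it replaces, a 1.1-fold higher number from compound 3 to compound 4 (0.05 log units; within the scatter), or from 3,5-dichlorophenyl, a 1.2-fold higher number from compound 1 to compound 4 (0.09 log units; within the scatter). The second step is new information: among these compounds, a different arrangement of the two chlorines on the ring leaves the number within the scatter, so compounds 1, 3 and 4 now form a single level, with compound 2 alone clearly lower. No measurement here explains why these groups give such similar numbers.

Still open, going by these compounds, is whether a phenyl ring carrying an amine or a carboxylic acid on the sulfonyl sulfur would give a number like that of compound 2 or like the other three. On these data alone, the effect of a longer chain in the shared core also remains unknown.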